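A few compounds are considered here, and "the series" means these few. Any claim that something is new, unique, unknown or untested is made for them only; others in the source may bear on it.

Of the compounds shown here, three from one series have been tested in a functional assay on MGC-803 cells (Homo sapiens) for inhibition, read by MTT assay, with a stated time of 72 h (on this read-out higher numbers stand for weaker inhibition and lower numbers for stronger inhibition), and a fourth awaits its result.

Compound 1 `Cc1ccc(CSc2nc3nc(C)cc(Nc4cc(-c5ccccc5)[nH]n4)n3n2)cc1` gives 6960 nM in this assay. Compound 2 `Cc1cc(Nc2cc(-c3ccccc3)[nH]n2)n2nc(SCc3ccc(C(F)(F)F)cc3)nc2n1` differs from it in a single spot, (trifluoromethyl in place of methyl on an aromatic carbon), and gives 3520 nM. The step is a 2.0-fold lower number from compound 1 to compound 2 (0.30 log units; within the scatter), so on the evidence of this pair alone the exchange of methyl for trifluoromethyl makes little difference that can be trusted.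

Compound 3 `Cc1ccc(Cn2ccc(Nc3cc(C)nc4nc(SCc5ccc(Br)cc5)nn34)n2)cc1` carries the same change-bearing side chain as compound 1 but is built on a different core; how the two cores differ is not broken down here. In this assay compound 3 gives 7420 nM, a number close to that of compound 1 and higher than that of compound 2.

Compound 4 `Cc1cc(Nc2ccn(Cc3ccc(C(F)(F)F)cc3)n2)n2nc(SCc3ccc(Br)cc3)nc2n1` stands to compound 3 as compound 2 stands to compound 1: the difference is trifluoromethyl in place of methyl on an aromatic carbon, the same change in the same kind of place. What compound 4 will show is not yet known. Because the earlier step was a 2.0-fold lower number from compound 1 to compound 2 (0.30 log units; within the scatter), the expected step here is a 1.9-fold lower number from compound 3 to compound 4 (0.27 log units; within the scatter), of a similar modest size. Within the data shown here, compound 4 is therefore estimated at 4000 nM in this assay, with a plausible range from 1800 nM to 9000 nM, a range that stays wide because only one earlier pair supports the expectation.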

Compound 4, half-maximal inhibitory concentration: 2590 nM
Compound 4: the middle estimate sits 1.5-fold (0.19 log units) above what was measured; the measured number falls inside the stated range.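

In this assay, putting trifluoromethyl in place of methyl gives a 2.9-fold lower number from compound 3 to compound 4 (0.46 log units; beyond the scatter), so on this core the step on its own stands clear of the ordinary spread of repeat measurements. Set beside the earlier step, the change looks much the same on both cores, and the two sizes cannot be told apart: the same change on two cores in this assay, a 2.0-fold lower number (0.30 log units; within the scatter) from compound 1 to compound 2 and a 2.9-fold lower number (0.46 log units; beyond the scatter) from compound 3 to compound 4, 1.4-fold (0.16 log units) apart, within the scatter of two such steps This shows that, for these two pairs, the exchange moves the number in the same direction by a comparable amount, although only the step on the second core is large enough to be trusted alone; it does not show that the change would carry over to a third core, and two pairs cannot establish a general rule or explain why the number falls.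

The compounds shown leave open what other groups would do in the same place, such as a chlorine atom, a methoxy group or an amine, since only methyl and trifluoromethyl can be compared here. They also leave open whether a longer chain in place of either group would continue the trend or break it, so any wider reading of this change needs further pairs.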